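The source may hold more compounds than are shown below. What is called first, only, known or untested is meant among the compounds shown, and "the series" means these compounds.

Of the compounds shown here, three that share one core have been measured in an assay on cells for displacement of a labelled ligand from Neuronal acetylcholine receptor; alpha3/beta4 (Homo sapiens); on this read-out lower numbers stand for stronger inhibition and higher numbers for weaker inhibition. Compound 1 `O=C(Nc1ccc(I)cc1)c1cncc(N2CC3CC(C2)N3)c1` gives 103 nM. Compound 2 `O=C(Nc1ccccc1F)c1cncc(N2CC3CC(C2)N3)c1` gives 102 nM. Compound 3 `O=C(Nc1ccc(F)cc1F)c1cncc(N2CC3CC(C2)N3)c1` gives 50 nM, the lowest of the three numbers; compound 2 stands nearest to it and compound 1 furthest. The step of a 1.0-fold lower number from compound 1 to compound 2 (0.00 log units; within the scatter) lies within the scatter, whereas a 2.1-fold lower number from compound 1 to compound 3 (0.31 log units; beyond the scatter) and a 2.0-fold lower number from compound 2 to compound 3 (0.31 log units; beyond the scatter) are modest but beyond it.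

Compound 4 `O=C(Nc1ccc(F)cc1)c1cncc(N2CC3CC(C2)N3)c1` has not yet been measured. It differs from compound 3 by hydrogen in place of fluoro on an aromatic carbon; the fluoro that leaves sits on an aromatic carbon of a six-membered aromatic ring of carbon only, ortho to a large group and meta to a fluoro group, so that, seen one bond further out, 2,4-difluorophenyl becomes 4-fluorophenyl. Going by the values given here, the one measured step that speaks to this change is a 2.0-fold lower number from compound 2 to compound 3 (0.31 log units; beyond the scatter), the same swap run in the opposite direction. Read backwards, that step suggests compound 4 is expected to show a modest rise, a 2.0-fold higher number from compound 3 to compound 4 (0.30 log units; within the scatter), because of a 2.0-fold lower number from compound 2 to compound 3 (0.31 log units; beyond the scatter). Compound 4 is therefore estimated at 100 nM, with a likely range from 50 nM to 200 nM.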

Compound 4, inhibition constant: 81 nM
Compound 4: middle estimate off by 1.2-fold (0.09 log units), on the high side; low and high end bracket the measured number.
By their numbers in this assay, from the lowest: compounds 3, 4, 2 and 1 (each within the scatter of the next, the first and the last beyond it).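

In this assay, going from 2,4-difluorophenyl to 4-fluorophenyl removes the fluoro that sits ortho to a large group and gives a 1.6-fold higher number from compound 3 to compound 4 (0.21 log units; within the scatter) as the result, so the loss of this fluoro cannot be told apart from repeat scatter. Going by these compounds alone, the only fluoro change seen earlier was the addition that turns 2-fluorophenyl into 2,4-difluorophenyl, which gave a 2.0-fold lower number from compound 2 to compound 3 (0.31 log units; beyond the scatter) as a modest step just past the scatter, so the two fluoro changes on this ring need not count equally. Replacing 2-fluorophenyl with 4-fluorophenyl gives a 1.3-fold lower number from compound 2 to compound 4 (0.10 log units; within the scatter) and replacing iodo with fluoro gives a 1.3-fold lower number from compound 1 to compound 4 (0.10 log units; within the scatter) in this series, so compound 4 cannot be ranked against either compound 2 or compound 1.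

Nothing at hand accounts for these small differences. As far as these compounds go, it also remains open whether a methoxy group, a chlorine or an amine on this aromatic carbon would move the number further than hydrogen or fluoro does, and where a phenyl ring with no substituent at all would fall.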